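Chain-length step in the aminoanilide arm of the series

The source may report more compounds than this note shows. Statements on the series, on what has been measured and on what is new or still open speak of the compounds shown alone.

Measured so far:
compound 1, `Cn1cc(-c2ccccc2Oc2ccccc2)c2cc(C(=O)NCCCCCCC(=O)NO)[nH]c2c1=O`, in an assay on isolated protein for inhibition of protein deacetylase HDAC6 (Homo sapiens), read by fluorescence (on this read-out higher numbers stand for weaker inhibition and lower numbers for stronger inhibition), gives 4.7 nM
compound 2, `Cn1cc(-c2ccccc2Oc2ccccc2)c2cc(C(=O)NCCCCC(=O)Nc3ccccc3N)[nH]c2c1=O`, in this assay is reported only as a limit, > 500 nM

Compound 1 sits at the strong end of the two numbers. For compound 2 this assay gives no number, only a limit. Within the data shown here, the single measured step, an at least 100-fold higher number from compound 1 to compound 2 (2.02 log units; beyond the scatter), ends at the limit of > 500 nM in this assay, at which 1 of the 2 values shown sits, so compound 2 stands at the weak end with its value known only as a limit.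

Compound 3, `Cn1cc(-c2ccccc2Oc2ccccc2)c2cc(C(=O)NCCCCCC(=O)Nc3ccccc3N)[nH]c2c1=O`, differs from compound 2 by ((2-aminophenyl)carbamoyl)methyl in place of (2-aminophenyl)carbamoyl on a saturated chain carbon, four bonds along the chain from an amide-type nitrogen. Among the measured compounds shown here, no measured step covers this change in chain length; the one measured step bears on it only in that it places compound 2 beyond the limit, so the starting point is itself a limit. The expectation is a step of no clear size, a step that the limit leaves unreadable from compound 2 to compound 3, with a high chance that this assay again reports only a limit. Compound 3 is therefore estimated at 1500 nM, between 400 nM and 6000 nM.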

Compound 3, half-maximal inhibitory concentration: > 500 nM
Compound 3: a limit, no number (the forecaster's own chance of this, stated with the estimate: 70%); the middle value does not contradict the limit.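

In this assay compound 3 gives > 500 nM, which is a limit and not a number. Going from (2-aminophenyl)carbamoyl to ((2-aminophenyl)carbamoyl)methyl at this saturated chain carbon therefore still gives no number for the aminoanilide arm, and the step between the two limits cannot be read. The gap to the hydroxamic acid stays large with the longer aminoanilide chain, with an at least 100-fold higher number from compound 1 to compound 3 (2.02 log units; beyond the scatter), and both aminoanilides now sit at the same reporting limit: the limit of > 500 nM in this assay, at which 2 of the 3 values shown sit.

From the compounds shown here alone, how far compound 2 and compound 3 lie beyond that limit stays open, so no chain-length trend can be stated for this arm. Also open, going by these compounds, is whether a longer chain, 2-((2-aminophenyl)carbamoyl)ethyl, or a carboxylic acid at this place would give a number in this assay.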